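The source may hold more compounds than are shown below. What is called first, only, known or untested is meant among the compounds shown, and "the series" means these compounds.

Going by the values given here, compound 2 `COc1cc2nc(N3CCC(C(=O)N4CCOCC4)CC3)nc(N)c2cc1OC` gives the lower of the two numbers so far in an assay on isolated protein for displacement of a labelled ligand from Adrenergic receptor alpha-1 (Rattus norvegicus) (a higher number here means a weaker inhibitor, a lower number a stronger inhibitor), where compound 2 gives 1.14 nM. Compound 1 `COc1cc2nc(N3CCC(C(=O)NCCO)CC3)nc(N)c2cc1OC` gives 1.73 nM in this assay, and the step of a 1.5-fold lower number from compound 1 to compound 2 (0.18 log units; within the scatter) shows that the two carboxamide variations made so far sit close together. Compound 3 `COc1cc2nc(N3CCC(C(=O)Nc4ccccc4)CC3)nc(N)c2cc1OC` has not yet been measured in this assay. The change from compound 2 is anilino in place of morpholin-4-yl on a carbonyl carbon. Among the compounds with values here, only one measured step bears on this position, the exchange at the same carbonyl carbon, which gave a 1.5-fold lower number from compound 1 to compound 2 (0.18 log units; within the scatter). That step stayed within the scatter, so the shared core appears to carry the binding while the amide substituent has mattered little. Compound 3 is therefore expected to show a step of about a 1.3-fold higher number from compound 2 to compound 3 (0.12 log units; within the scatter), no more than the scatter allows. Compound 3 is estimated at 1.5 nM, with a range from 0.5 nM to 5 nM.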

Compound 3, inhibition constant: 0.47 nM
Beside the measured number, compound 3's estimate is 3.2-fold (0.50 log units) above it; measured number outside the range, below it.
By their numbers in this assay, from the lowest: compound 3; then compounds 2 and 1 (each within the scatter of the next).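

The amide substituent is less silent in this assay than the earlier pair suggested: anilino in place of morpholin-4-yl gives a 2.4-fold lower number from compound 2 to compound 3 (0.38 log units; beyond the scatter) and phenyl in place of 2-hydroxyethyl on the amide-type nitrogen gives a 3.7-fold lower number from compound 1 to compound 3 (0.57 log units; beyond the scatter), both modest but beyond the scatter. Changes on this carbonyl carbon can therefore move the number, and compound 3, the only one of the three carrying an aromatic ring there, gives the lowest. No measurement offered here accounts for this difference.

The compounds shown leave open whether the phenyl ring itself matters, as a saturated cyclohexyl ring on the same amide nitrogen would test. They also leave open how a benzyl group, or a phenyl ring bearing a methoxy or chloro substituent, would behave.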